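Acetamido replaces nitro on compound 2

The source may report more compounds than this note shows. Statements on the series, on what has been measured and on what is new or still open speak of the compounds shown alone.

In a functional assay on SMMC-7721 cells (Homo sapiens) for cytotoxicity, read by MTT assay, with a stated time of 24 h (on this read-out higher numbers stand for weaker inhibition and lower numbers for stronger inhibition), compound 1 `COc1ccc(/C=C2\CN(C)C/C(=C\c3cccnc3)C2=O)c(OC)c1OC` gives 13700 nM as its measured value. Compound 2 `O=C1/C(=C/c2cccnc2)CN(S(=O)(=O)c2ccc([N+](=O)[O-])cc2)C/C1=C\c1ccccc1F` has no number, only a limit of the assay at > 20000 nM as its reading. Compound 3 `CC(=O)Nc1ccc(S(=O)(=O)N2C/C(=C\c3cccnc3)C(=O)/C(=C/c3ccccc3F)C2)cc1` differs from compound 2 in one place, with acetamido in place of nitro on an aromatic carbon. For the measured compounds named here, no measured pair shows what this swap does in this assay. A small step towards stronger inhibition, or none beyond the scatter, is expected. The estimated step is small (an at least 1.3-fold lower number from compound 2 to compound 3 (0.12 log units; that floor lies within the scatter)). Compound 3 is expected near 15000 nM (estimated range 6000 nM to 35000 nM).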

Compound 3, half-maximal inhibitory concentration: 10900 nM
The estimate for compound 3 lay 1.4-fold (0.14 log units) above the measured number; the range from low to high includes it.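

For compound 2, > 20000 nM in this assay is a limit of the assay, not a number. Putting acetamido in place of nitro, on an aromatic carbon para to a large group, gives a reading that can be stated as a number, with an at least 1.8-fold lower number from compound 2 to compound 3 (0.26 log units; that floor lies within the scatter). That step is only a floor because one end of it is a limit: the limit of > 20000 nM in this assay, at which 1 of the 3 values shown sits.

On these data alone, the true size of the step stays open. So does what an amine or a carboxylic acid would do at this place.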